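The source may report more compounds than this note shows. Statements on the series, on what has been measured and on what is new or still open speak of the compounds shown alone.

In an in vitro ADME assay on microsomes from liver (Homo sapiens) for metabolic stability, tested at 1 uM (a lower number here means slower removal, a higher number faster removal of the compound), compound 3 (`Cc1cc(CCC#N)cc(C)c1Oc1cc(Nc2ccc(C#N)cc2)c(N)cc1C(F)(F)F`) gives 120 mL.min-1.g-1. This number lies within the scatter of the two other measured compounds, compound 1 (`Cc1cc(/C=C/C#N)cc(C)c1Oc1cc(Nc2ccc(C#N)cc2)c(N)cc1C(N)=O`) and compound 2 (`Cc1cc(/C=C/C#N)cc(C)c1Oc1cc(Nc2ccc(C#N)cc2)c(N)cc1[N+](=O)[O-]`). Compound 4 (`Cc1cc(/C=C/C#N)cc(C)c1Oc1cc(Nc2ccc(C#N)cc2)c(N)cc1C(F)(F)F`) has not been measured yet. It differs from compound 3 in one place: 2-cyanoethenyl in place of 2-cyanoethyl on an aromatic carbon. In words, 2-cyanoethenyl stands in place of 2-cyanoethyl on an aromatic carbon.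

Among the measured compounds shown here, no measured pair shows this change on its own. For the measured compounds named here, the only measured step, a 1.3-fold lower number from compound 1 to compound 2 (0.12 log units; within the scatter), concerns a different change, nitro in place of carbamoyl, and it stays within the scatter. Still, compound 1, at 200 mL.min-1.g-1, and compound 2, at 150 mL.min-1.g-1, already carry 2-cyanoethenyl, and neither number stands apart from that of compound 3. No step beyond the scatter is therefore expected in this assay, and the data give no firm direction. The expected step is a 1.3-fold higher number from compound 3 to compound 4 (0.10 log units; within the scatter). For compound 4 the estimate is 150 mL.min-1.g-1, with an expected range from 80 mL.min-1.g-1 to 260 mL.min-1.g-1.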

Compound 4, intrinsic clearance in microsomes: 150 mL.min-1.g-1
Beside the measured number, compound 4's estimate shows no gap at the digits printed; measured number inside the range.
By their numbers in this assay, from the lowest: compounds 3, 2, 4 and 1 (each within the scatter of the next).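

In this assay the swap of 2-cyanoethyl for 2-cyanoethenyl can now be read on its own, and it gives a 1.3-fold higher number from compound 3 to compound 4 (0.10 log units; within the scatter) with trifluoromethyl held constant, so adding this one double bond on the aromatic carbon stays within the scatter in this pair. With 2-cyanoethenyl held constant, trifluoromethyl in place of nitro gives no change at the digits printed from compound 2 to compound 4 (within the scatter) and trifluoromethyl in place of carbamoyl gives a 1.3-fold lower number from compound 1 to compound 4 (0.12 log units; within the scatter) and neither step leaves the scatter. Nothing shown here speaks to what lies behind these results.

The compounds shown carry only 2-cyanoethyl or 2-cyanoethenyl at this position, so the outcome with an amine, a carboxylic acid or a longer chain there remains open. Among the compounds shown here, the same swap is seen only with trifluoromethyl present, so its step with nitro or carbamoyl in that place also remains open.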